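An Open-Chain Amine on a Thiazole Replaces the Azetidine

The source may hold more compounds than are shown below. What is called first, only, known or untested is meant among the compounds shown, and "the series" means these compounds.

Compound 1 `O=C(NC[C@H]1CN(c2ccc(-n3cccc3CN3CCC3)cc2)C(=O)O1)c1ccc(Cl)s1` is the reference point of this small set. In an assay on isolated protein (plasma) for inhibition of coagulation factor X (Oryctolagus cuniculus) (a higher number here means a weaker inhibitor, a lower number a stronger inhibitor), compound 1 gives 810 nM, the lowest of the three numbers measured. Compound 2 `O=C(NC[C@H]1CN(c2ccc(-n3cccc3CN3CCCCC3)cc2)C(=O)O1)c1ccc(Cl)s1` gives 2890 nM in this assay, and compound 3 `O=C(NC[C@H]1CN(c2ccc(-n3cccc3CN3CCCC3)cc2F)C(=O)O1)c1ccc(Cl)s1` gives 2450 nM. Compound 3 differs from compound 1 in two places at once, so its value is noted without a single step attached to it.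

Going by the values given here, the one clean step in this assay is a 3.6-fold higher number from compound 1 to compound 2 (0.55 log units; beyond the scatter), a change confined to the size of the saturated ring on the saturated chain carbon. Compound 4 `CCNCc1csc(-c2ccc(N3C[C@H](CNC(=O)c4ccc(Cl)s4)OC3=O)cc2)n1` is a larger departure: 4-((ethylamino)methyl)-1,3-thiazol-2-yl in place of 2-((azetidin-1-yl)methyl)-1H-pyrrol-1-yl on an aromatic carbon. The aromatic ring itself is exchanged, and the cyclic amine gives way to an ethylamino group. Among the compounds with values here, no measured step covers an exchange of this kind. Within the data shown here, the only guidance is that altering the amine on that saturated chain carbon moved the number beyond the scatter toward weaker inhibition, and a change touching both the amine and the ring can reasonably be expected to move it at least as far, with wide uncertainty. The expected step is a 2.2-fold higher number from compound 1 to compound 4 (0.35 log units; beyond the scatter). Compound 4 is therefore estimated at 1800 nM, with a range from 450 nM to 7000 nM.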

Compound 4, half-maximal inhibitory concentration: 890 nM
Estimate against measurement, compound 4: 2.0-fold (0.31 log units) above; low and high end bracket the measured number.
By their numbers in this assay, from the lowest: compounds 1 and 4 (each within the scatter of the next); then compounds 3 and 2 (each within the scatter of the next).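

In this assay the exchange on this aromatic carbon, para to a large group, gives a 1.1-fold higher number from compound 1 to compound 4 (0.04 log units; within the scatter) and leaves the two compounds indistinguishable, although the aromatic ring and the amine both change at once. Swapping only the saturated ring of the amine had given a 3.6-fold higher number from compound 1 to compound 2 (0.55 log units; beyond the scatter) and thus a clear shift, so the size of that step proves no guide to a larger exchange: here a 4-((ethylamino)methyl)-1,3-thiazol-2-yl group, with an open-chain amine, stands in place of the 2-((azetidin-1-yl)methyl)-1H-pyrrol-1-yl group without the number leaving the scatter. Nothing given here bears on why the larger exchange leaves the number within the scatter while the smaller one does not.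

Because the ring and the amine change together in this step, the compounds shown cannot say what each contributes alone, and an azetidin-1-ylmethyl group on the 1,3-thiazol-2-yl ring, or an ethylaminomethyl group on the 1H-pyrrol-1-yl ring, would separate the two. From the compounds shown here alone, it also stays open how far the amine on the thiazole can vary, for instance as a primary amine, a dimethylamino group or a longer propylamino chain.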